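Anilino for Ethoxy, Tried on a Second Core

The source may hold more compounds than are shown below. What is called first, only, known or untested is meant among the compounds shown, and "the series" means these compounds.

Compound 1, `CCOC(=O)C1=C(C)NC(=S)NC1c1cn(-c2ccccc2)nc1-c1ccccc1`: 42000 nM
Compound 2, `CC1=C(C(=O)Nc2ccccc2)C(c2cn(-c3ccccc3)nc2-c2ccccc2)NC(=S)N1`: 88200 nM
Compound 3, `CCOC(=O)C1=C(C)NC(=O)NC1c1cn(-c2ccccc2)nc1-c1ccc(Cl)cc1`: 68800 nM

All three numbers come from a functional assay on MCF7 cells (Homo sapiens) for inhibition, read by sulforhodamine B assay, with a stated time of 24 h; on this read-out higher numbers stand for weaker inhibition of growth and lower numbers for stronger inhibition of growth. Compound 2 differs from compound 1 in one place only, (anilino in place of ethoxy on a carbonyl carbon), and that single change made a 2.1-fold higher number from compound 1 to compound 2 (0.32 log units; beyond the scatter). Compound 3 carries a different core; how the two cores differ is not broken down here. The values of compound 3 and compound 2 lie within the usual scatter of each other, so no order between them can be read; the same holds for compound 3 against compound 1.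

Compound 4, `CC1=C(C(=O)Nc2ccccc2)C(c2cn(-c3ccccc3)nc2-c2ccc(Cl)cc2)NC(=O)N1`, has not yet been measured. It differs from compound 3 by anilino in place of ethoxy on a carbonyl carbon, the same change at the same kind of carbonyl carbon as between compound 1 and compound 2. For the measured compounds named here, because the only earlier example of this change read a 2.1-fold higher number from compound 1 to compound 2 (0.32 log units; beyond the scatter), a step of similar size is expected, a 2.1-fold higher number from compound 3 to compound 4 (0.32 log units; beyond the scatter), resting on that one precedent alone. Compound 4 is therefore estimated to give about 145000 nM in this assay, most likely somewhere between 60000 nM and 350000 nM.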

Compound 4, concentration for 50% growth inhibition: 65500 nM
For compound 4 the middle estimate is 2.2-fold (0.35 log units) above the measured one; low and high end bracket the measured number.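

In this assay, putting anilino in place of ethoxy on a carbonyl carbon gave a 1.1-fold lower number from compound 3 to compound 4 (0.02 log units; within the scatter), so on this core the swap leaves no difference that can be read. Set beside the earlier example, the two steps cannot be told apart: the same change on two cores in this assay, a 2.1-fold higher number (0.32 log units; beyond the scatter) from compound 1 to compound 2 and a 1.1-fold lower number (0.02 log units; within the scatter) from compound 3 to compound 4, 2.2-fold (0.34 log units) apart, within the scatter of two such steps. This does not show that the core alters the effect of the change, yet it does not show that the change carries over at a fixed size either, since one step lies beyond the scatter, the other lies within it, and two pairs are too few to settle the matter.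

The compounds shown leave open how other groups on the same carbonyl carbon would read, such as a methylamino group, a longer chain like butoxy, or a free carboxylic acid. They also leave open whether further matched pairs on these two cores would bring the size of this step into clearer view.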